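The source may hold more compounds than are shown below. What is called first, only, known or untested is meant among the compounds shown, and "the series" means these compounds.

Compound 1 `O=C(CSc1nc(-c2ccccc2)c(C(=O)O)c(=O)[nH]1)Nn1c(COc2ccc(Cl)cc2Cl)nc2ccccc2c1=O` and compound 2 `O=C(CSc1nc(-c2ccc(Cl)cc2)c(C(=O)O)c(=O)[nH]1)Nn1c(COc2ccc(Cl)cc2Cl)nc2ccccc2c1=O` share one core, compound 2 carrying (chloro in place of hydrogen on an aromatic carbon). In a functional assay on the whole organism (strain albino) for inhibition, with Rattus norvegicus as the target, read by paw edema, with stated times of 1 h and 2 h, at a dose of 100 mg/kg by the oral route (a higher number here means more inhibition at the dose given (going by the name of the read-out), a lower number less inhibition), compound 1 gives 68.4%, and compound 2 gives 61.4%, so the step of a number 7 percentage points lower from compound 1 to compound 2 (within the scatter) is small. Compound 3 `N#Cc1c(Nc2ccccc2)nc(SCC(=O)Nn2c(COc3ccc(Cl)cc3Cl)nc3ccccc3c2=O)nc1-c1ccc(Cl)cc1` is built on another core; the difference between the two cores is not broken down here. In this assay compound 3 gives 50.9%, the lowest of the three. Compound 4 `N#Cc1c(Nc2ccc(Cl)cc2)nc(SCC(=O)Nn2c(COc3ccc(Cl)cc3Cl)nc3ccccc3c2=O)nc1-c1ccc(Cl)cc1` differs from compound 3 by chloro in place of hydrogen on an aromatic carbon, the same change made between compound 1 and compound 2, here on the anilino ring. Since a number 7 percentage points lower from compound 1 to compound 2 (within the scatter) stayed within the scatter, a similarly small step is expected for compound 4, as a number 3.9 percentage points lower from compound 3 to compound 4 (within the scatter). Compound 4 is therefore estimated at 47%, between 33% and 61%.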

Compound 4, a percentage reported as inhibition, in the whole organism at one dose (the size of the read-out at that dose, not a potency): 61.4%
Beside the measured number, compound 4's estimate is 14.4 percentage points below it; the measured number lies above the stated range.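

Putting chloro in place of hydrogen on the anilino ring gives a number 10.5 percentage points higher from compound 3 to compound 4 (beyond the scatter) in this assay. Set beside the earlier step, this shows that the result of the change on one core does not simply carry over to the other: the same change on two cores in this assay, a number 7 percentage points lower (within the scatter) from compound 1 to compound 2 and a number 10.5 percentage points higher (beyond the scatter) from compound 3 to compound 4, 17.5 percentage points apart, beyond the scatter of two such steps Each core offers only one pair, and the chloro sits on a different ring in each, so these compounds do not show whether the core or the ring accounts for the gap.

Going by these compounds, it remains open whether other groups in the same place on the anilino ring, such as fluoro or methoxy, would follow the chloro. A single pair per core also leaves open how well either step would repeat.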